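Methoxy for Fluoro on the Aryl Amide End

This account rests on a few compounds, and the source may have more. Where it says the series, first, only, none or still open, it means among the compounds named here.

The three measured compounds, with their values:
compound 1 `O=C(CCCCCCNC(=O)C(O)(O)C(F)(F)F)Nc1nc2ccccc2s1`: 2370 nM
compound 2 `CC(=O)c1ccc(NC(=O)CCCCCCNC(=O)C(O)(O)C(F)(F)F)cc1`: 12100 nM
compound 3 `O=C(CCCCCCNC(=O)C(O)(O)C(F)(F)F)Nc1ccc(F)cc1`: 7570 nM

In a functional assay on HCT-116 cells (Homo sapiens) for inhibition, read by colorimetric assay, with a stated time of 3 days (on this read-out lower numbers stand for stronger inhibition and higher numbers for weaker inhibition), compound 3 stands second highest of the three numbers. Its nearest neighbour is compound 2, with a 1.6-fold lower number from compound 2 to compound 3 (0.20 log units; within the scatter), while its furthest is compound 1, with a 3.2-fold higher number from compound 1 to compound 3 (0.50 log units; beyond the scatter). Compound 4 `COc1ccc(NC(=O)CCCCCCNC(=O)C(O)(O)C(F)(F)F)cc1` carries methoxy in place of fluoro on an aromatic carbon. For the measured compounds named here, the step that bears most on this is the one from compound 2 to compound 3, where one group on the same aromatic carbon was exchanged for another and the result stayed within the scatter. The larger steps, a 5.1-fold higher number from compound 1 to compound 2 (0.71 log units; beyond the scatter) and a 3.2-fold higher number from compound 1 to compound 3 (0.50 log units; beyond the scatter), replaced the whole aryl group and so bear less. A change within the scatter is therefore expected here, with a 1.2-fold higher number from compound 3 to compound 4 (0.08 log units; within the scatter). Compound 4 is estimated at 9000 nM, between 3000 nM and 27000 nM.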

Compound 4, half-maximal inhibitory concentration: 4520 nM
Estimate against measurement, compound 4: 2.0-fold (0.30 log units) above, within the range that was stated.
By their numbers in this assay, from the lowest: compounds 1, 4, 3 and 2 (each within the scatter of the next, the first and the last beyond it).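

In this assay, methoxy in place of fluoro gives a 1.7-fold lower number from compound 3 to compound 4 (0.22 log units; within the scatter) and so stays within the scatter, as the swap from acetyl to fluoro did at this same aromatic carbon. Methoxy in place of acetyl gives a 2.7-fold lower number from compound 2 to compound 4 (0.43 log units; beyond the scatter) and is the first step at this carbon to pass beyond the scatter, while replacing 1,3-benzothiazol-2-yl with 4-methoxyphenyl gives a 1.9-fold higher number from compound 1 to compound 4 (0.28 log units; within the scatter) and is the first such replacement to stay within it. Nothing measured here explains these differences.

Going by these compounds, how an amine or a carboxylic acid on this carbon would compare remains open.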